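A few compounds are considered here, and "the series" means these few. Any claim that something is new, unique, unknown or untested is made for them only; others in the source may bear on it.

Compound 1 `CCNCC(=O)Nc1cc(OC)ccc1C(=O)c1ccc(OC)c2c1OC(C)(C)C=C2` and compound 2 `CCNCC(=O)Nc1cc(OC)ccc1C(=O)c1ccc(OC)c2c1C=CC(C)(C)O2` are built from the same atoms joined differently, and the difference between their two cores is not broken down here. In a functional assay on MCF7 cells (Homo sapiens) for antiproliferative activity, read by MTT assay, with a stated time of 48 h (on this read-out higher numbers stand for weaker inhibition and lower numbers for stronger inhibition), compound 1 gives 5200 nM, while compound 2 gives 7230 nM, two numbers that lie within the scatter of each other. Compound 3 `COc1ccc(C(=O)c2ccc(OC)c3c2OC(C)(C)C=C3)c(NC(=O)CN(C)C)c1` carries one change relative to compound 1, (dimethylamino in place of ethylamino on a saturated chain carbon bound to a carbonyl carbon), and in this assay compound 3 gives 2680 nM, a step of a 1.9-fold lower number from compound 1 to compound 3 (0.29 log units; within the scatter). Compound 4 `COc1ccc(C(=O)c2ccc(OC)c3c2C=CC(C)(C)O3)c(NC(=O)CN(C)C)c1` bears the same change made on the core of compound 2, (dimethylamino in place of ethylamino on a saturated chain carbon bound to a carbonyl carbon). Because the step of a 1.9-fold lower number from compound 1 to compound 3 (0.29 log units; within the scatter) lies within the scatter, a step of the same modest size is expected here: a 1.9-fold lower number from compound 2 to compound 4 (0.27 log units; within the scatter). Compound 4 is therefore estimated at 3900 nM in this assay, with a likely range from 1800 nM to 8500 nM.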

Compound 4, half-maximal inhibitory concentration: 6530 nM
For compound 4 the middle estimate is 1.7-fold (0.22 log units) below the measured one; the range from low to high includes it.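

In this assay, placing dimethylamino where ethylamino stood on the core of compound 2 gives a small step, a 1.1-fold lower number from compound 2 to compound 4 (0.04 log units; within the scatter). Set beside the earlier step, the same change reads alike on the two cores: the same change on two cores in this assay, a 1.9-fold lower number (0.29 log units; within the scatter) from compound 1 to compound 3 and a 1.1-fold lower number (0.04 log units; within the scatter) from compound 2 to compound 4, 1.8-fold (0.24 log units) apart, within the scatter of two such steps. Both steps lie within the scatter, so this pair of cores gives no sign that the core alters the step, but it does not show that the change itself shifts the read-out, or that it would read the same on any other core.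

The compounds shown leave open how a cyclic amine such as pyrrolidine or morpholine would read in this assay in place of these two groups. They also leave open what a longer chain carrying the amine would give.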